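The source may hold more compounds than are shown below. What is called first, only, known or untested is meant among the compounds shown, and "the series" means these compounds.

In an ADME assay on L6 cells (Rattus norvegicus) for cytotoxicity, read by resazurin assay (a higher number here means a weaker inhibitor, a lower number a stronger inhibitor), two compounds with the same core have been measured. Compound 1 `N=C(N)c1ccc2[nH]c(-c3ccc4nc(-c5ccccc5F)[nH]c4c3)nc2c1` gives 26.8 ug/mL and compound 2 `N=C(N)c1ccc2[nH]c(-c3ccc4nc(-c5ccc(F)cc5)[nH]c4c3)nc2c1` gives 2.48 ug/mL, the lower of the two numbers. The change leading to compound 3 `N=C(N)c1ccc2[nH]c(-c3ccc4nc(-c5ccc(F)c(F)c5)[nH]c4c3)nc2c1` is fluoro in place of hydrogen on an aromatic carbon, which turns 4-fluorophenyl into 3,4-difluorophenyl. Among the measured compounds shown here, only one measured step bears on it, an 11-fold lower number from compound 1 to compound 2 (1.03 log units; beyond the scatter), and it is large. That step moves a fluoro rather than adding one, however, and compound 3 keeps the fluoro of compound 2. For the measured compounds named here, no measured step shows what a second fluoro does. In this assay, no step beyond the scatter is therefore expected, though the uncertainty is wide in either direction. The expected step is a 1.0-fold higher number from compound 2 to compound 3 (0.02 log units; within the scatter). Compound 3 is estimated at 2.6 ug/mL, with an expected range of 0.9 ug/mL to 8 ug/mL.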

Compound 3, half-maximal inhibitory concentration: 29.8 ug/mL
Beside the measured number, compound 3's estimate is 11-fold (1.06 log units) below it; the measured number lies above the stated range.
By their numbers in this assay, from the lowest: compound 2; then compounds 1 and 3 (each within the scatter of the next).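

In this assay, a second fluoro, ortho to the first, gives a 12-fold higher number from compound 2 to compound 3 (1.08 log units; beyond the scatter), so this ring carbon responds strongly to the entry of a single fluorine atom. The other new step, a 1.1-fold higher number from compound 1 to compound 3 (0.05 log units; within the scatter), puts 3,4-difluorophenyl level with 2-fluorophenyl, leaving compound 2 and its 4-fluorophenyl alone with the lower number among these three compounds. Nothing available accounts for the size of this step.

The compounds shown leave open whether the change is specific to fluoro or would also follow from chloro, methyl, methoxy or an amine on the same carbon. They also leave open what 3-fluorophenyl, carrying its fluoro on that carbon with no fluoro at the 4-position, would give.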